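The source may hold more compounds than are shown below. What is called first, only, known or untested is meant among the compounds shown, and "the series" means these compounds.

Measured so far in an assay on isolated protein with metabotropic glutamate receptor 1 (Homo sapiens) as the target; on this read-out higher numbers stand for an effect only at larger amounts of compound and lower numbers for an effect already at smaller amounts:
compound 1 `CC(C)(C)c1nn(CC(=O)Nc2sc3c(c2C(N)=O)CCCC3)cc1CNC1CC1` gives 1580 nM
compound 2 `CC(C)NCc1cn(CC(=O)Nc2sc3c(c2C(N)=O)CCCC3)nc1C(F)(F)F` gives 3160 nM
compound 3 `CC(C)NCc1cn(CC(=O)Nc2sc3c(c2C(N)=O)CCCC3)nc1C(C)(C)C` gives 1580 nM

Compound 2 carries the highest of the three numbers, but neither gap separates it from the others: a 2.0-fold lower number from compound 2 to compound 3 (0.30 log units; within the scatter), and the gap between compound 2 and compound 1 is the same size and likewise within the scatter. On these numbers the three compounds are not ordered.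

Compound 4 `NCc1cn(CC(=O)Nc2sc3c(c2C(N)=O)CCCC3)nc1C(F)(F)F` differs from compound 2 at the amine nitrogen: hydrogen in place of isopropyl on an amine nitrogen. The measured step that bears on this position is no change at the digits printed from compound 1 to compound 3 (within the scatter), where one small group on the same nitrogen was exchanged for another with a flat result. The other step, a 2.0-fold lower number from compound 2 to compound 3 (0.30 log units; within the scatter), sits on the aromatic carbon and says nothing about the amine. Within the data shown here, no measured pair removes the substituent from the nitrogen altogether, so the case for a bare amino group rests on that single flat step and is indirect. A small step is therefore expected in this assay , slightly upward if anything, and most likely within the scatter.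

Compound 4 is estimated at 4000 nM with a range from 1600 nM to 10000 nM. The expected step is a 1.3-fold higher number from compound 2 to compound 4 (0.10 log units; within the scatter).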

Compound 4, half-maximal effective concentration: 794 nM
Beside the measured number, compound 4's estimate is 5.0-fold (0.70 log units) above it; measured number below the stated range.
By their numbers in this assay, from the lowest: compounds 4, 1, 3 and 2 (each within the scatter of the next, the first and the last beyond it).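

In this assay, among these compounds, hydrogen in place of isopropyl on the amine nitrogen gives a 4.0-fold lower number from compound 2 to compound 4 (0.60 log units; beyond the scatter), the only step so far that lies beyond the scatter, though it is modest in size. The earlier exchange on this nitrogen, isopropyl in place of cyclopropyl, gave no change at the digits printed from compound 1 to compound 3 (within the scatter), so the flat result between those two groups did not carry over to removing the substituent altogether. The number at this position therefore responds to the change from isopropylamino to amino, at least with trifluoromethyl on the aromatic carbon. The available data offer no explanation for this step.

Going by these compounds, it remains open whether the same step appears with tert-butyl on the aromatic carbon, and whether a methyl or ethyl group on the nitrogen gives a number closer to that of compound 4 or that of compound 2. Also open, on these data alone, is whether the nitrogen has to remain an amine at all, a question that an acetamide or a hydroxymethyl group in place of the aminomethyl group would address.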